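This account rests on a few compounds, and the source may have more. Where it says the series, first, only, none or still open, it means among the compounds named here.

Compound 2 `COc1cc(-c2ccc(C#N)cc2)ccc1C(O)c1ccnc(Nc2ccc(C#N)cc2)n1` has the same atoms and bonds as compound 1 `COc1cc(-c2ccc(C#N)cc2)ccc1[C@H](O)c1ccnc(Nc2ccc(C#N)cc2)n1` and compound 3 `COc1cc(-c2ccc(C#N)cc2)ccc1[C@@H](O)c1ccnc(Nc2ccc(C#N)cc2)n1`. In an ADME assay on MT4 cells (Homo sapiens) for cytotoxicity, read by MTT assay, with a stated time of 5 days (on this read-out higher numbers stand for lower toxicity in this test and lower numbers for higher toxicity in this test), compound 2 gives 13200 nM and compound 1 gives 9070 nM, so the two cannot be told apart on these numbers. Moving on to compound 3 leaves the atoms untouched and alters only how one stereocentre is drawn: the two compounds have the same atoms and bonds; at least one stereo element is drawn with a configuration in one of them and without one in the other: 1 of 1 stereo elements differ; a stereocentre at a saturated chain carbon is drawn without a configuration in compound 2 and R in compound 3. That stereocentre, at a saturated chain carbon, is drawn without a configuration in compound 2 and R in compound 3. Going by the values given here, the one measured step of this kind starts from compound 1, where the same carbon is drawn S, and it is small: a 1.5-fold higher number from compound 1 to compound 2 (0.16 log units; within the scatter). Among the compounds with values here, with only that step as a guide, no change beyond the scatter is expected in this assay. The expected step is a 1.1-fold higher number from compound 2 to compound 3 (0.03 log units; within the scatter). The estimated value for compound 3 is 14000 nM, with a range of 7000 nM to 28000 nM.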

Compound 3, half-maximal cytotoxic concentration: 33100 nM
The estimate for compound 3 lay 2.4-fold (0.37 log units) below the measured number; measured number outside the range, above it.
By their numbers in this assay, from the lowest: compounds 1 and 2 (each within the scatter of the next); then compound 3.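

In this assay, the arrangement at this stereocentre now makes a measurable difference, which the earlier pair, within the scatter of each other, could not show: the new steps are a 2.5-fold higher number from compound 2 to compound 3 (0.40 log units; beyond the scatter) and a 3.6-fold higher number from compound 1 to compound 3 (0.56 log units; beyond the scatter). Both steps are modest, but compound 3, drawn R, has the highest number of the three and so is the least toxic in this test. The step between the two defined forms is the cleanest comparison, because nothing but the drawn arrangement separates them: the fact that compounds 1 and 3 differ only in the configuration as drawn

The drawing of compound 2 does not tell what it contains at this carbon, so its place in the order is harder to interpret. The compounds shown also leave open whether the R form would keep its edge if an amine replaced the hydroxyl group on this carbon.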